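The source may hold more compounds than are shown below. What is called first, only, known or untested is meant among the compounds shown, and "the series" means these compounds.

Three compounds share one core and differ only in the aromatic group attached to it. Compound 1 `CC(C)n1cc(-c2cc(C(O)(C(F)(F)F)C(F)(F)F)cnc2N2CCN(S(=O)(=O)c3ccc(N)nc3)CC2)cn1` gives 38 mL.min-1.g-1 in an ADME assay (liver) for metabolic stability, with Liver microsome (Homo sapiens) as the target, using microsomes and NADPH, with a stated time of 30 min, tested at 1 uM; a higher number here means faster removal of the compound, a lower number slower removal. Compound 2 `NC(=O)c1cccc(-c2cc(C(O)(C(F)(F)F)C(F)(F)F)cnc2N2CCN(S(=O)(=O)c3ccc(N)nc3)CC2)c1` gives 17 mL.min-1.g-1, and compound 3 `CS(=O)(=O)c1ccc(-c2cc(C(O)(C(F)(F)F)C(F)(F)F)cnc2N2CCN(S(=O)(=O)c3ccc(N)nc3)CC2)cc1` gives 32 mL.min-1.g-1. Compound 3 thus stands second highest of the three, though its gaps to compound 1 and to compound 2 both lie within the scatter. Compound 4 `Cc1nc2cc(-c3cc(C(O)(C(F)(F)F)C(F)(F)F)cnc3N3CCN(S(=O)(=O)c4ccc(N)nc4)CC3)ccc2o1` alters the same position once more: 2-methyl-1,3-benzoxazol-5-yl in place of 4-(methylsulfonyl)phenyl on an aromatic carbon. All three measured steps exchange this very group: a 2.2-fold lower number from compound 1 to compound 2 (0.35 log units; beyond the scatter), a 1.2-fold lower number from compound 1 to compound 3 (0.07 log units; within the scatter) and a 1.9-fold higher number from compound 2 to compound 3 (0.27 log units; within the scatter). Such exchanges have shifted the number only slightly, so a step of a 1.1-fold lower number from compound 3 to compound 4 (0.03 log units; within the scatter) is expected, within or close to the scatter. Compound 4 is therefore estimated at 30 mL.min-1.g-1, between 14 mL.min-1.g-1 and 65 mL.min-1.g-1.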

Compound 4, intrinsic clearance in microsomes: < 14 mL.min-1.g-1
Compound 4: no number, only a limit; the forecaster's own chance of this, stated with the estimate: 5%; middle value at least 2.1-fold (0.33 log units) away from the limit.
By their numbers in this assay, from the lowest: compounds 2, 3 and 1 (each within the scatter of the next, the first and the last beyond it). At a limit, below all of these: compound 4.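

Compound 4 has only a limit, not a number, in this assay: the limit of < 14 mL.min-1.g-1 in this assay, at which 1 of the 4 values shown sits. Even so, this position can move the number at least as far as any earlier exchange, with an at least 2.2-fold lower number from compound 3 to compound 4 (0.35 log units; beyond the scatter) and an at least 2.7-fold lower number from compound 1 to compound 4 (0.43 log units; beyond the scatter), while an at least 1.2-fold lower number from compound 2 to compound 4 (0.08 log units; that floor lies within the scatter), so compound 4 cannot yet be separated from compound 2. The two groups exchanged have equal counts of heavy atoms and hydrogen-bond acceptors, so those counts alone do not track this change. On these data alone, the actual number for compound 4 remains open. Also open, as far as these compounds go, is whether replacing the methyl of 2-methyl-1,3-benzoxazol-5-yl with an amine or a longer chain would keep the change.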